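The compounds below may be only part of what the source reports. "The series", "measured", "known", "first", "only" and "open" are said of these compounds alone.

Series notes.

Compound 1 `Cc1nc2c(OCc3ccccc3)cccn2c1CCC#N` — 40%
Compound 2 `CC(=O)OCc1c(C)nc2c(OCc3ccccc3)cccn12` — 88%
Compound 3 `Cc1nc2c(OCc3ccccc3)cccn2c1COC(=O)c1cccnc1` — 87%

In a functional assay on the whole organism with Rattus norvegicus as the target, with a stated time of 4 h, at a dose of 40 mg/kg by the intraperitoneal route (a lower number here means less inhibition, a higher number more inhibition at the dose given (going by the name of the read-out)), compound 1 stands lowest of the three; compound 3 is nearest and compound 2 furthest, both beyond the scatter. Compound 4 `Cc1nc2c(OCc3ccccc3)cccn2c1COC(=O)N(C)C` differs from compound 1 by (dimethylcarbamoyl)oxy in place of cyanomethyl on a saturated chain carbon bound to an aromatic carbon. Within the data shown here, two measured steps bear on this change, both starting from compound 1: a number 48 percentage points higher from compound 1 to compound 2 (beyond the scatter) and a number 47 percentage points higher from compound 1 to compound 3 (beyond the scatter). Between the two measured replacements the difference is small: a number 1 percentage points lower from compound 2 to compound 3 (within the scatter). Since both measured replacements of cyanomethyl on the same saturated chain carbon gave a large rise, a large upward step is expected for compound 4 as well, with some allowance for an untested group: a number 40 percentage points higher from compound 1 to compound 4 (beyond the scatter). Compound 4 is therefore estimated at 80%, within 55% to 95%.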

Compound 4, a percentage reported as inhibition, in the whole organism at one dose (the size of the read-out at that dose, not a potency): 75%
Compound 4: middle estimate off by 5 percentage points, on the high side; low and high end bracket the measured number.
By their numbers in this assay, from the lowest: compound 1; then compound 4; then compounds 3 and 2 (each within the scatter of the next).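

In this assay a third oxygen-linked group on the saturated chain carbon bound to an aromatic carbon also gives a large rise over the nitrile-bearing chain (a number 35 percentage points higher from compound 1 to compound 4 (beyond the scatter)). The group on the carbonyl carbon now matters, if only modestly: dimethylamino gives a lower number than pyridin-3-yl (a number 12 percentage points lower from compound 3 to compound 4 (beyond the scatter)) and than methyl (a number 13 percentage points lower from compound 2 to compound 4 (beyond the scatter)).

No measurement at hand accounts for these differences. Still open, from the compounds shown here alone, is how a simple amine or a carboxylic acid on that chain carbon, or a longer chain on the carbonyl carbon, would read.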